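Benzyl Ring Changes in the Three Measured Compounds

The compounds below may be only part of what the source reports. "The series", "measured", "known", "first", "only" and "open" are said of these compounds alone.

Compound 3 `O=S(=O)(NCCCNCc1ccc(Cl)cc1)c1cc(C(F)(F)F)cc(C(F)(F)F)c1` gives 2400 nM in a functional assay on MCF7 cells (Homo sapiens) for inhibition, read by MTT assay, with a stated time of 72 h (on this read-out higher numbers stand for weaker inhibition of growth and lower numbers for stronger inhibition of growth), which places it level with compound 1 `O=S(=O)(NCCCNCc1ccc(Cl)c(Cl)c1)c1cc(C(F)(F)F)cc(C(F)(F)F)c1` at the digits shown; in this assay compound 1 gives 2400 nM. Together they are the lowest two of the three numbers, with compound 2 `COc1ccc(CNCCCNS(=O)(=O)c2cc(C(F)(F)F)cc(C(F)(F)F)c2)cc1` nearest, as compound 2 gives 2500 nM in this assay. All three sit within the scatter of one another: a 1.0-fold higher number from compound 1 to compound 2 (0.02 log units; within the scatter), no change at the digits printed from compound 1 to compound 3 (within the scatter), and a 1.0-fold lower number from compound 2 to compound 3 (0.02 log units; within the scatter).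

Compound 4 `COc1ccccc1CNCCCNS(=O)(=O)c1cc(C(F)(F)F)cc(C(F)(F)F)c1` is not yet measured. The change from compound 3 is 2-methoxyphenyl in place of 4-chlorophenyl on a saturated chain carbon bound to an amine nitrogen. For the measured compounds named here, the steps that bear on it are the exchange of methoxy and chloro on the aromatic ring, a 1.0-fold lower number from compound 2 to compound 3 (0.02 log units; within the scatter), and the exchange of the whole benzyl ring, a 1.0-fold higher number from compound 1 to compound 2 (0.02 log units; within the scatter), neither of which moved the number beyond the scatter. On that basis the expected step is a 1.0-fold higher number from compound 3 to compound 4 (0.02 log units; within the scatter), that is, no change beyond the scatter in either direction. Compound 4 is therefore estimated at 2500 nM in this assay, with a range from 1200 nM to 5200 nM.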

Compound 4, concentration for 50% growth inhibition: 2600 nM
Beside the measured number, compound 4's estimate is 1.0-fold (0.02 log units) below it, and the stated range covers the measured number.
By their numbers in this assay, from the lowest: compounds 1, 3, 2 and 4 (each within the scatter of the next).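

Moving the methoxy group from 4-methoxyphenyl to 2-methoxyphenyl gives a 1.0-fold higher number from compound 2 to compound 4 (0.02 log units; within the scatter) in this assay, so this relocation of the group on the benzyl ring stays within the scatter. The replacement of a chlorinated ring by 2-methoxyphenyl reads the same way, with a 1.1-fold higher number from compound 3 to compound 4 (0.03 log units; within the scatter) and a 1.1-fold higher number from compound 1 to compound 4 (0.03 log units; within the scatter) for the 4-chlorophenyl and 3,4-dichlorophenyl cases, and none of the four compounds goes against this flat picture at the saturated chain carbon bound to an amine nitrogen. No measurement at hand bears on why these numbers stay together.

On these data alone, whether this flat reading would hold with a nitrile or a carboxylic acid on the ring remains open. Also open, as far as these compounds go, is how the number would respond to a longer chain carrying the amine.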